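The source may hold more compounds than are shown below. What is called first, only, known or untested is meant among the compounds shown, and "the series" means these compounds.

- compound 1 `CCCc1ccc(NC2=CC(=O)c3nc4n(c3C2=O)[C@H]2OC[C@@H](O)[C@H]2OC4)cc1`: 4660 nM
- compound 2 `O=C1C=C(Nc2ccc(I)cc2)C(=O)c2c1nc1n2[C@H]2OC[C@@H](O)[C@H]2OC1`: 2230 nM

In a functional assay on MCF7 cells (Homo sapiens) for inhibition, read by sulforhodamine B assay (a higher number here means a weaker inhibitor, a lower number a stronger inhibitor), compound 2 gives the lower of the two numbers, 2230 nM. Compound 3 `O=C1C=C(Nc2cccc(Cl)c2)C(=O)c2c1nc1n2[C@H]2OC[C@@H](O)[C@H]2OC1` differs from it in one place: 3-chlorophenyl in place of 4-iodophenyl on an amine nitrogen. Among the compounds with values here, only one measured step bears on this change: a 2.1-fold lower number from compound 1 to compound 2 (0.32 log units; beyond the scatter), with iodo in place of propyl on an aromatic carbon. Within the data shown here, no measured compound carries the 3-chlorophenyl group, so a small step of no firm direction is expected in this assay. The expected step is a 1.2-fold higher number from compound 2 to compound 3 (0.07 log units; within the scatter). For compound 3 the estimated value is 2600 nM, within an expected range of 900 nM to 7500 nM.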

Compound 3, half-maximal inhibitory concentration: 4720 nM
Estimate against measurement, compound 3: 1.8-fold (0.26 log units) below; low and high end bracket the measured number.
By their numbers in this assay, from the lowest: compound 2; then compounds 1 and 3 (each within the scatter of the next).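

In this assay, 3-chlorophenyl in place of 4-iodophenyl gives a 2.1-fold higher number from compound 2 to compound 3 (0.33 log units; beyond the scatter) and shows that the lower number of compound 2 does not extend to every halogen-bearing phenyl group on this amine nitrogen. Against 4-propylphenyl, the same group gives a 1.0-fold higher number from compound 1 to compound 3 (0.01 log units; within the scatter) and leaves these two compounds level within the scatter. Nothing measured here explains the difference between 4-iodophenyl and 3-chlorophenyl.

The compounds shown leave open whether the halogen or its ring position sets this step. A 4-chlorophenyl group on the same amine nitrogen would separate the two.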